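The source may report more compounds than this note shows. Statements on the series, on what has been measured and on what is new or still open speak of the compounds shown alone.

Measured compounds in a functional assay on HepG2 cells (Homo sapiens) for inhibition, read by MTT assay, with a stated time of 72 h; a higher number here means a weaker inhibitor, a lower number a stronger inhibitor:
- compound 1, `CC(C)c1cccc(-n2cc(COc3cccc(NC(=O)Nc4ccc(Cl)c(C(F)(F)F)c4)c3)nn2)c1`: 3250 nM
- compound 2, `CC(C)c1ccc(-n2cc(COc3cccc(NC(=O)Nc4ccc(Cl)c(C(F)(F)F)c4)c3)nn2)cc1`: 2470 nM

Compound 2 gives the lower of the two numbers, though its gap to compound 1 is within the scatter: a 1.3-fold lower number from compound 1 to compound 2 (0.12 log units; within the scatter). That step, the only one measured, shifts the isopropyl group on the same ring and changes little.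

Compound 3, `O=C(Nc1cccc(OCc2cn(-c3ccccc3Cl)nn2)c1)Nc1ccc(Cl)c(C(F)(F)F)c1`, brings a different kind of change: 2-chlorophenyl in place of 4-isopropylphenyl on an aromatic nitrogen. For the measured compounds named here, no measured pair shows a chlorine in place of an isopropyl group on this ring, so the one step on record only says that the aryl group on the ring nitrogen tolerates rearrangement without a step beyond the scatter. On that basis no shift beyond the scatter is expected for compound 3 in this assay, with the estimated step being a 1.1-fold higher number from compound 2 to compound 3 (0.04 log units; within the scatter). The estimate for compound 3 is 2700 nM, in the range 900 nM to 8000 nM, and the range is kept wide since the entering group is new to the series.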

Compound 3, half-maximal inhibitory concentration: 1960 nM
The estimate for compound 3 lay 1.4-fold (0.14 log units) above the measured number; the range from low to high includes it.
By their numbers in this assay, from the lowest: compounds 3, 2 and 1 (each within the scatter of the next).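

In this assay, the change to 2-chlorophenyl on the ring nitrogen gives a 1.3-fold lower number from compound 2 to compound 3 (0.10 log units; within the scatter) and a 1.7-fold lower number from compound 1 to compound 3 (0.22 log units; within the scatter), so the steps stay within the scatter from either isopropylphenyl compound. Until now, only a shift of the isopropyl group on the same ring was on record; these steps extend that to a different substituent, with chlorine entering in place of isopropyl, and to a smaller aryl group, across these three compounds only. No available data explain why the aryl group on the ring nitrogen has so little effect on the number.

Open, on these data alone, is whether a phenyl ring carrying an amine or a carboxylic acid, or a longer alkyl chain in place of the aryl group, would give a step beyond the scatter. The other end of the core, with its chlorine and trifluoromethyl, is the same in all three compounds, so they say nothing about that part.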